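Swapping bromo for chloro on a cytotoxic compound

A few compounds are considered here, and "the series" means these few. Any claim that something is new, unique, unknown or untested is made for them only; others in the source may bear on it.

compound 1 `O=C(Nc1cc(C(F)(F)F)cc(C(F)(F)F)c1)c1ccc(Br)cc1O`: 930 nM
compound 2 `O=C(Nc1ccc(Cl)c(C(F)(F)F)c1)c1cc(F)ccc1O`: 530 nM

In a functional assay on Jurkat cells (Homo sapiens) for cytotoxicity, read by luminescence and CellTiter-Glo, with a stated time of 3 days (on this read-out lower numbers stand for stronger inhibition and higher numbers for weaker inhibition), compound 1 gives 930 nM and compound 2 gives 530 nM. These two numbers lie within the usual scatter of each other, so they cannot be ranked. Compound 3 `O=C(Nc1cc(C(F)(F)F)cc(C(F)(F)F)c1)c1ccc(Cl)cc1O` keeps the core of compound 1 but has chloro in place of bromo on an aromatic carbon, meta to a hydroxy group and para to a large group (chloro in place of bromo on an aromatic carbon). For the measured compounds named here, the two measured compounds differ in more than one place, so no measured pair shows this swap on its own. With no measured guide to a direction, no change beyond the scatter is expected in this assay. The estimated step of a 1.2-fold lower number from compound 1 to compound 3 (0.07 log units; within the scatter) is therefore small. The estimate for compound 3 is 800 nM, with an expected range from 350 nM to 1800 nM.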

Compound 3, half-maximal inhibitory concentration: 570 nM
For compound 3 the middle estimate is 1.4-fold (0.15 log units) above the measured one, and the stated range covers the measured number.
By their numbers in this assay, from the lowest: compounds 2, 3 and 1 (each within the scatter of the next).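

In this assay, the swap of bromo for chloro on this aromatic carbon reads as a 1.6-fold lower number from compound 1 to compound 3 (0.21 log units; within the scatter), so at this position of the core of compound 1 the two halogens cannot be told apart. The earlier compounds shown here could not show this, since compound 1 and compound 2 differ in more than one place and left the swap without a clean comparison. No other measurement bears on this result, so it stands as a plain observation.

As far as these compounds go, whether a group of a different kind on this carbon, such as an amine, a methoxy group or a carboxylic acid, would keep the number in the same range remains open. From the compounds shown here alone, it is also open whether bromo and chloro would read alike on a different core, such as that of compound 2.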